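This account rests on a few compounds, and the source may have more. Where it says the series, first, only, none or still open, it means among the compounds named here.

Measured compounds:
compound 1, `CN1CCC(C(=O)c2cccc(NC(=O)c3ccc(F)cc3)c2O)CC1` — 1100 nM
compound 2, `Cc1c(NC(=O)c2ccc(F)cc2)cccc1C(=O)C1CCN(C)CC1` — 870 nM
compound 3, `CN1CCC(C(=O)c2cc(F)cc(NC(=O)c3ccc(F)cc3)c2)CC1` — 41 nM

Among the three numbers in an assay on isolated protein for binding affinity to 5-hydroxytryptamine receptor 1F (Homo sapiens), read by radioligand binding (a lower number here means a stronger inhibitor, a higher number a weaker inhibitor), compound 1 stands highest. The nearest is compound 2, and that gap, a 1.3-fold lower number from compound 1 to compound 2 (0.10 log units; within the scatter), lies within the scatter, so the two cannot be set in order. Compound 3 lies far lower, yet it differs from compound 1 in more than one place, so its value is shown only for comparison and does not give a single step.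

Compound 4, `CN1CCC(C(=O)c2cccc(NC(=O)c3ccc(F)cc3)c2F)CC1`, has not been measured in this assay. It differs from compound 1 in one respect: fluoro in place of hydroxy on an aromatic carbon. For the measured compounds named here, the only measured step that touches this change is the one in which the same hydroxy gave way to methyl, a 1.3-fold lower number from compound 1 to compound 2 (0.10 log units; within the scatter), which stayed within the scatter. Going by the values given here, on this basis a fluoro in its place is not expected to move the number far either, although the substituent here is a different one and the single precedent is thin. The expected step, a 1.6-fold lower number from compound 1 to compound 4 (0.20 log units; within the scatter), is therefore small and uncertain in direction. Compound 4 is estimated at 700 nM, with a range from 250 nM to 2000 nM.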

Compound 4, inhibition constant: 8.3 nM
The estimate for compound 4 lay 84-fold (1.93 log units) above the measured number, and the stated range ends above it.
By their numbers in this assay, from the lowest: compound 4; then compound 3; then compounds 2 and 1 (each within the scatter of the next).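

In this assay, this carbon, ortho to a large group, proved far more sensitive to its substituent than the earlier pair suggested: the step (a 1.3-fold lower number from compound 1 to compound 2 (0.10 log units; within the scatter)) had shown no separation between hydroxy and methyl, yet fluoro stands well apart from both, with a 130-fold lower number from compound 1 to compound 4 (2.12 log units; beyond the scatter) and a 100-fold lower number from compound 2 to compound 4 (2.02 log units; beyond the scatter). The position is therefore not indifferent to what it carries, and a single exchange that moves the number little says little about the next substituent placed there. Why fluoro parts so sharply from the other two groups cannot be told, as nothing measured here speaks to the reason.

Going by these compounds, whether a chloro, a methoxy or an amino group on this carbon, or a plain hydrogen, would follow fluoro or stay with hydroxy and methyl remains open. For the compounds shown here, it is also open whether this gain belongs to fluoro at this carbon alone or to fluoro on this ring more generally, since compound 3, at 41 nM, is joined to the others by no single step.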